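This account rests on a few compounds, and the source may have more. Where it says the series, first, only, none or still open, it means among the compounds named here.

Three compounds have been measured in an assay on isolated protein for antagonist activity at Voltage-dependent L-type calcium channel subunit alpha-1C (Cavia porcellus), with a stated time of 15 min; on this read-out lower numbers stand for stronger inhibition and higher numbers for weaker inhibition:

Compound 1, `CCOC(=O)C1=C(C)NC(C)=C(C(=O)OCC(C)C)C1c1csc(-c2ccc(Cl)cc2)n1`, gives 15400 nM.
Compound 2, `CCOC(=O)C1=C(C)NC(C)=C(C(=O)OC(C)(C)C)C1c1csc(-c2ccc(Cl)cc2)n1`, gives 91000 nM.
Compound 3, `CCOC(=O)C1=C(C)NC(C)=C(C(=O)OC2CCCC2)C1c1csc(-c2ccc(Cl)cc2)n1`, gives 8380 nM.

Compound 3 shows the lowest number of the three, but its gap to compound 1 is small: a 1.8-fold lower number from compound 1 to compound 3 (0.26 log units; within the scatter). Its gap to compound 2 is clear, an 11-fold lower number from compound 2 to compound 3 (1.04 log units; beyond the scatter), and the tert-butyl ester also stood apart from the isobutyl ester, a 5.9-fold higher number from compound 1 to compound 2 (0.77 log units; beyond the scatter).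

Compound 4, `CCOC(=O)C1=C(C)NC(C)=C(C(=O)OC2CCCCC2)C1c1csc(-c2ccc(Cl)cc2)n1`, differs from compound 3 in one place: cyclohexyl in place of cyclopentyl on an oxygen next to a carbonyl group. For the measured compounds named here, no measured step exchanges one ring for another, so the only guides are the steps among the open-chain and cyclopentyl esters. The large loss appeared with tert-butyl, whereas isobutyl and cyclopentyl sat close together. Growing the ring by one carbon looks more like the latter kind of change. The step expected here, a 1.0-fold lower number from compound 3 to compound 4 (0.02 log units; within the scatter), should stay within the scatter. In this assay compound 4 is therefore estimated at 8000 nM, with a range from 3000 nM to 25000 nM.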

Compound 4, half-maximal inhibitory concentration: 100000 nM
The estimate for compound 4 lay 13-fold (1.10 log units) below the measured number; the measured number lies above the stated range.
By their numbers in this assay, from the lowest: compounds 3 and 1 (each within the scatter of the next); then compounds 2 and 4 (each within the scatter of the next).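

At this place, on an oxygen next to a carbonyl group, growing the ring by one carbon is not a minor change: in this assay, cyclohexyl in place of cyclopentyl gives a large step (a 12-fold higher number from compound 3 to compound 4 (1.08 log units; beyond the scatter)). Compound 4 cannot be told apart from the tert-butyl ester (a 1.1-fold higher number from compound 2 to compound 4 (0.04 log units; within the scatter)) and stands clearly apart from the isobutyl ester (a 6.5-fold higher number from compound 1 to compound 4 (0.81 log units; beyond the scatter)), so having a ring here does not by itself keep the lower number of compound 3. No measurement shown here explains the difference between the two rings.

Still open, going by these compounds, is where the sharp change sets in, since a smaller ring such as cyclobutyl has no value here. The response to a longer open chain such as hexyl, or to a ring holding an oxygen such as tetrahydropyranyl, is equally unknown.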